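The source may report more compounds than this note shows. Statements on the series, on what has been measured and on what is new or still open speak of the compounds shown alone.

Measured compounds in a functional assay on A549 cells (Homo sapiens) for cytotoxicity, with a stated time of 48 h; on this read-out lower numbers stand for stronger inhibition of growth and higher numbers for weaker inhibition of growth:
- compound 1, `Cc1cc(-c2cc(N3C[C@H](O)[C@@H](O)C3)ccc2O)nc(N)n1`: 2000 nM
- compound 2, `Nc1nc(-c2cc(N3C[C@H](O)[C@@H](O)C3)ccc2O)cc(C2CCCCCC2)n1`: 600 nM
- compound 3, `Nc1nc(-c2cc(N3C[C@H](O)[C@@H](O)C3)ccc2O)cc(C2CCCNC2)n1`: a limit, > 10000 nM

Compound 1 gives the highest of the two numbers shown in this assay; compound 2 gives a number that is lower, as a 3.3-fold lower number from compound 1 to compound 2 (0.52 log units; beyond the scatter) shows. For compound 3 this assay reports only a limit, (the limit of > 10000 nM in this assay, at which 1 of the 3 values shown sits), and no number.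

Compound 4, `CCc1cc(-c2cc(N3C[C@H](O)[C@@H](O)C3)ccc2O)nc(N)n1`, has not yet been measured in this assay. It differs from compound 1 in one place: methyl in place of hydrogen on a saturated chain carbon bound to an aromatic carbon. The same difference, cut one bond further out, reads methyl to ethyl.

Two measured steps start from the same place on the shared core. Cycloheptyl in place of methyl on an aromatic carbon gave a 3.3-fold lower number from compound 1 to compound 2 (0.52 log units; beyond the scatter), a modest lowering. Piperidin-3-yl in place of methyl on an aromatic carbon gave an at least 5.0-fold higher number from compound 1 to compound 3 (0.69 log units; beyond the scatter), a rise to the limit. Methyl in place of hydrogen is a far smaller change than either, so the expected step in this assay is small, a 1.3-fold lower number from compound 1 to compound 4 (0.12 log units; within the scatter), and likely within the scatter. Compound 4 is therefore estimated at 1500 nM, with a range from 600 nM to 4000 nM.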

Compound 4, concentration for 50% growth inhibition: 3000 nM
Beside the measured number, compound 4's estimate is 2.0-fold (0.30 log units) below it; the measured number falls inside the stated range.
By their numbers in this assay, from the lowest: compound 2; then compounds 1 and 4 (each within the scatter of the next). At a limit, above all of these: compound 3.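

Going from methyl to ethyl at this position does not move the number beyond the scatter in this assay (a 1.5-fold higher number from compound 1 to compound 4 (0.18 log units; within the scatter)), so one added carbon on the saturated chain leaves growth inhibition where compound 1 had it. Ethyl does not match the cycloheptyl group (a 5.0-fold higher number from compound 2 to compound 4 (0.70 log units; beyond the scatter)), yet it stands clear of the piperidin-3-yl group (an at least 3.3-fold lower number from compound 3 to compound 4 (0.52 log units; beyond the scatter)), so among these groups only the two ring groups separate from methyl and ethyl. The value of compound 3 in that comparison is a limit and not a number: the limit of > 10000 nM in this assay, at which 1 of the 4 values shown sits.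

As far as these compounds go, whether a longer chain such as butyl or hexyl moves the number toward that of compound 2 stays open. So does whether an open-chain amine at this position behaves like the piperidin-3-yl group.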